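Urea in place of hexanamide on a sulfonate ester core

The source may hold more compounds than are shown below. What is called first, only, known or untested is meant among the compounds shown, and "the series" means these compounds.

In a functional assay on M21 cells (Homo sapiens) for antiproliferative activity, read by sulforhodamine B assay, with a stated time of 48 h (a lower number here means a stronger inhibitor, a higher number a weaker inhibitor), three compounds with a shared core have been measured. Compound 1 `CCCCCC(=O)Nc1ccc(S(=O)(=O)Oc2ccccc2C(C)C)cc1` gives 6700 nM. Compound 2 `CCCCCC(=O)Nc1ccc(S(=O)(=O)Oc2ccccc2I)cc1` gives 11000 nM, and compound 3 `O=C(CCCl)Nc1ccc(S(=O)(=O)Oc2ccccc2I)cc1` gives 12000 nM. Compound 1 carries the lowest of these numbers, but its steps to the others, a 1.6-fold higher number from compound 1 to compound 2 (0.22 log units; within the scatter) and the further gap to compound 3, remain within the scatter, so no order among the three can be claimed.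

Compound 4 `CC(C)c1ccccc1OS(=O)(=O)c1ccc(NC(=O)NCCCCl)cc1` differs from compound 1 as follows: (3-chloropropyl)amino in place of pentyl on a carbonyl carbon. The measured step closest to this change is a 1.1-fold higher number from compound 2 to compound 3 (0.04 log units; within the scatter), where a chloro-terminated chain replaced an alkyl chain on the amide side without moving the number beyond the scatter. The step of a 1.6-fold higher number from compound 1 to compound 2 (0.22 log units; within the scatter) at the other end of the molecule was likewise flat. Neither step bears on the new donor introduced here, so this assay is expected to show no step beyond the scatter, a 1.2-fold higher number from compound 1 to compound 4 (0.08 log units; within the scatter). Compound 4 is therefore estimated at 8000 nM, within 3000 nM to 22000 nM.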

Compound 4, half-maximal inhibitory concentration: 9300 nM
Compound 4: the middle estimate sits 1.2-fold (0.07 log units) below what was measured, within the range that was stated.
By their numbers in this assay, from the lowest: compounds 1, 4, 2 and 3 (each within the scatter of the next).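

In this assay, the exchange at this carbonyl carbon gives a 1.4-fold higher number from compound 1 to compound 4 (0.14 log units; within the scatter), so compound 1 and compound 4 cannot be told apart. The earlier compounds shown here had varied this side only with an amide kept in place, whereas here a chain nitrogen with its hydrogen-bond donor arrives on the carbonyl carbon, together with a terminal chlorine, and the number stays within the scatter. No measurement offered here explains this result.

The change brings in the nitrogen and the chlorine together, so the compounds shown do not separate what each contributes. As far as these compounds go, what a urea ending in a plain propyl chain, a terminal amine or a carboxylic acid would give in this assay remains open.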